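This account rests on a few compounds, and the source may have more. Where it says the series, first, only, none or still open, it means among the compounds named here.

Measured compounds:
- compound 1, `COc1cc2c(cc1OC)CN(c1ccc(C=O)cc1)CC2`: 61%
- compound 2, `COc1cc2c(cc1OC)CN(c1ccc(F)cc1)CC2`: 56.8%

Going by the values given here, in an ADME assay on microsomes from liver (Homo sapiens) for metabolic stability, read by LC-MS, with a stated time of 10 min, tested at 500 uM (on this read-out lower numbers stand for a less stable compound and higher numbers for a more stable compound), compound 2 gives 56.8%, the lowest of the two numbers; its nearest neighbour is compound 1 with 61%, and the one measured step, a number 4.2 percentage points lower from compound 1 to compound 2 (within the scatter), lies within the scatter. Compound 3, `COc1cc2c(cc1OC)CN(c1cccnc1)CC2`, has not yet been measured. It differs from compound 2 by pyridin-3-yl in place of 4-fluorophenyl on an amine nitrogen in a ring. Among the compounds with values here, no measured step touches this place, so the only guide is that the single known change left the number essentially unmoved. For compound 3 a step of about a number 0.2 percentage points higher from compound 2 to compound 3 (within the scatter) is therefore expected, nothing beyond the scatter. The estimate for compound 3 is 57%, expected to fall between 35% and 78%.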

Compound 3, percent of the compound remaining in the Homo sapiens assay: 66.9%
Compound 3: middle estimate off by 9.9 percentage points, on the low side, within the range that was stated.
By their numbers in the Homo sapiens assay, from the lowest: compounds 2, 1 and 3 (each within the scatter of the next, the first and the last beyond it).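

This position on the amine nitrogen in a ring can move the stability read-out: in the Homo sapiens assay, pyridin-3-yl in place of 4-fluorophenyl gives a number 10.1 percentage points higher from compound 2 to compound 3 (beyond the scatter), whereas the earlier formyl-to-fluoro change stayed within the scatter. In a physicochemical assay for lipophilicity, at pH 7.4 (on this read-out lower numbers stand for lower lipophilicity and higher numbers for higher lipophilicity), compound 2 gives 4.5 and compound 3 gives 3.7, so the same change also shifts this second read-out. This single pair cannot show whether the two shifts are linked. Still open, on these data alone, is how a pyrimidin-5-yl or a cyclohexyl group would behave at this place.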